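A few compounds are considered here, and "the series" means these few. Any claim that something is new, unique, unknown or untested is made for them only; others in the source may bear on it.

Compound 2 `C=CC[C@H]1C[C@@H]([C@@H](O)c2ccccc2)CO[C@@H]1c1ccccc1` gives the highest number of the three measured compounds in a functional assay on HL-60 cells (Homo sapiens) for cytotoxicity, read by WST assay, with a stated time of 48 h (on this read-out lower numbers stand for stronger inhibition and higher numbers for weaker inhibition), with compound 2 at 36000 nM. Compound 1 `CCCCCC/C=C/C[C@H]1C[C@@H]([C@@H](O)c2ccccc2)CO[C@@H]1c1ccccc1` gives 4990 nM, and compound 3 `O=[N+]([O-])c1cccc(/C=C/C[C@H]2C[C@@H]([C@@H](O)c3ccccc3)CO[C@@H]2c2ccccc2)c1` gives 6350 nM. Compound 4 `O[C@@H](c1ccccc1)[C@H]1CO[C@H](c2ccccc2)[C@@H](C/C=C/c2ccncc2)C1` has not yet been measured. Its difference from compound 2 is 2-(pyridin-4-yl)ethenyl in place of vinyl on a saturated chain carbon bound to a saturated ring carbon.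

For the measured compounds named here, two measured steps bear on this change. The step of a 7.2-fold higher number from compound 1 to compound 2 (0.86 log units; beyond the scatter) shows that shortening the chain on that saturated chain carbon from the group of 8 heavy atoms to the group of 2 heavy atoms raised the number well beyond the scatter; compound 4 restores a group of 8 heavy atoms at the same place. The step of a 1.3-fold higher number from compound 1 to compound 3 (0.10 log units; within the scatter) shows that exchanging hexyl for 3-nitrophenyl on the double-bonded chain carbon left the number within the scatter, so an aromatic ring in that position read much like the hexyl chain. On that basis a step downward in this assay roughly the size of the step from compound 1 to compound 2, reversed, is expected, and the expected step is a 5.1-fold lower number from compound 2 to compound 4 (0.71 log units; beyond the scatter). Compound 4 is therefore estimated at 7000 nM, within a range from 2500 nM to 20000 nM.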

Compound 4, half-maximal inhibitory concentration: > 100000 nM
Compound 4 was reported as a limit (the forecaster's own chance of this, stated with the estimate: 5%); middle value at least 14-fold (1.15 log units) from the limit.
By their numbers in this assay, from the lowest: compounds 1 and 3 (each within the scatter of the next); then compound 2. At a limit, above all of these: compound 4.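

Compound 4 stands in this assay only as a limit, not as a number: the limit of > 100000 nM in this assay, at which 1 of the 4 values shown sits.

The larger group of 8 heavy atoms on the saturated chain carbon bound to a saturated ring carbon therefore does not by itself lower the number, as 2-(pyridin-4-yl)ethenyl in place of vinyl gives an at least 2.7-fold higher number from compound 2 to compound 4 (0.44 log units; beyond the scatter), whereas the hexyl-bearing group of compound 1 stands on the lower side of compound 2 in a 7.2-fold higher number from compound 1 to compound 2 (0.86 log units; beyond the scatter). On the double-bonded chain carbon, an aromatic ring no longer reads like the hexyl chain in every case: pyridin-4-yl gives an at least 15-fold higher number from compound 3 to compound 4 (1.19 log units; beyond the scatter) and an at least 20-fold higher number from compound 1 to compound 4 (1.30 log units; beyond the scatter), while 3-nitrophenyl gave only a 1.3-fold higher number from compound 1 to compound 3 (0.10 log units; within the scatter).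

The compounds shown leave open whether the change follows from the ring nitrogen of pyridin-4-yl or from the loss of the nitro group, a question that a plain phenyl or a pyridin-3-yl on that double-bonded chain carbon would address. On these data alone, the true size of the steps to compound 4 also stays open.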